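The compounds below may be only part of what the source reports. "The series", "measured", "known", "first", "only" and "open" are said of these compounds alone.

Measured so far:
Compound 1 `C/C(=N\O)C(=O)NCCCCCC(=O)Nc1ccccc1` gives > 100000 nM in a functional assay on HCT-116 cells (Homo sapiens) for inhibition, read by colorimetric assay, with a stated time of 3 days; on this read-out higher numbers stand for weaker inhibition and lower numbers for stronger inhibition; this is a limit of the assay, not a number.
Compound 2 `O=C(CCCCCCNC(=O)C(O)(O)C(F)(F)F)Nc1ccc(F)cc1F` gives 18500 nM in this assay.
Compound 3 `O=C(CCCCCCNC(=O)C(O)(O)C(F)(F)F)Nc1ccc(S(F)(F)(F)(F)F)cc1` gives 9110 nM in this assay.

Among the two numbers shown, compound 2 stands highest, so it is the weaker inhibitor of the pair; compound 3 gives the nearer and lower number, and the gap between them lies beyond the usual scatter. Compound 1 sits at the limit of > 100000 nM in this assay, at which 1 of the 3 values shown sits, and so cannot be ranked against either.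

The step to be followed leads from compound 2 to compound 4 `O=C(CCCCCCNC(=O)C(O)(O)C(F)(F)F)Nc1cccc(Br)c1`. The change is 3-bromophenyl in place of 2,4-difluorophenyl on an amide-type nitrogen. For the measured compounds named here, no step between measured compounds is available to guide the reading of this change, so the expectation rests on compounds 2 and 3 alone. In this assay a small step is expected, toward a slightly lower number, and most likely not beyond the scatter: a 1.5-fold lower number from compound 2 to compound 4 (0.19 log units; within the scatter). Compound 4 is estimated at 12000 nM, within a range from 4000 nM to 40000 nM.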

Compound 4, half-maximal inhibitory concentration: 3060 nM
The estimate for compound 4 lay 3.9-fold (0.59 log units) above the measured number; the measured number lies below the stated range.
By their numbers in this assay, from the lowest: compound 4; then compound 3; then compound 2. At a limit, above all of these: compound 1.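

Putting 3-bromophenyl in place of 2,4-difluorophenyl on an amide-type nitrogen gives, in this assay, a 6.0-fold lower number from compound 2 to compound 4 (0.78 log units; beyond the scatter), so a single change at this place can shift the number well beyond the scatter. Compound 3 gives 9110 nM and compound 4 gives 3060 nM, so the group in compound 4 now carries the lowest number among the three measured compounds that share this chain. None of the information available accounts for why this change lowers the number.

From the compounds shown here alone, it remains open whether the gain follows from the bromine or from the loss of the two fluorines, and a plain phenyl group on the same nitrogen would help separate the two. Going by these compounds, how a pyridyl group or a carboxylic acid on the ring would read in this assay also remains open.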